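This account rests on a few compounds, and the source may have more. Where it says the series, first, only, none or still open, it means among the compounds named here.

Compound 1 `CN(C)CC#Cc1cc2ncnc(Nc3ccc(OCc4cccc(F)c4)c(Cl)c3)c2s1` gives in an ADME assay on NIH3T3 cells (Mus musculus) for cytotoxicity; on this read-out lower numbers stand for higher toxicity in this test and higher numbers for lower toxicity in this test > 50 uM, a limit of the assay rather than a number.
Compound 2 `Fc1cccc(COc2ccc(Nc3ncnc4cc(C#CCN5CCNCC5)sc34)cc2Cl)c1` gives in this assay > 50 uM, again a limit of the assay.
Among the compounds with values here, compound 3 `CN(C)CC#Cc1cc2c(Nc3ccc(OCc4cccc(F)c4)c(Cl)c3)ncnc2s1` gives in this assay 41 uM, the only number among the three.

Compound 1 and compound 3 are built from the same atoms joined differently; the difference between their two cores is not broken down here. Compound 2 differs from compound 1 by piperazin-1-yl in place of dimethylamino on a saturated chain carbon bound to a triple-bonded carbon. The step that the two limits leave unreadable from compound 1 to compound 2 cannot be read, since both ends sit at the limit of > 50 uM in this assay, at which 2 of the 3 values shown sit. Compound 3 stands at a number, but within the usual scatter of this kind of measurement it is hard to separate from that limit.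

Compound 4 `Fc1cccc(COc2ccc(Nc3ncnc4sc(C#CCN5CCNCC5)cc34)cc2Cl)c1` is not yet measured. It differs from compound 3 by piperazin-1-yl in place of dimethylamino on a saturated chain carbon bound to a triple-bonded carbon; the place is the same in both words and sense as for the change from compound 1 to compound 2, so the two changes are the same change made on two cores. Within the data shown here, because the one measured instance of that change left a step that the two limits leave unreadable from compound 1 to compound 2 unreadable, there is no direction to borrow from it, and the expectation for the step of a 1.2-fold higher number from compound 3 to compound 4 (0.07 log units; within the scatter) is estimated as essentially flat, resting on the value of compound 3, 41 uM. Compound 4 is therefore expected to show about 48 uM in this assay, with a plausible range from 25 uM to 100 uM, and a fair chance that the assay again reports only a limit.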

Compound 4, half-maximal toxic concentration: 3.9 uM
Beside the measured number, compound 4's estimate is 12-fold (1.09 log units) above it; the whole stated range lies above it.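

In this assay, piperazin-1-yl in place of dimethylamino on a saturated chain carbon bound to a triple-bonded carbon gives an 11-fold lower number from compound 3 to compound 4 (1.02 log units; beyond the scatter) and so, on the core of compound 3, marks a large move towards higher toxicity in this test. This single readable instance does not show whether the same change would have a similar effect on another core, or whether the lower number belongs to the core of compound 3 alone. The same change on the core of compound 1 cannot be read, so it neither supports nor contradicts the result on the core of compound 3, because both of its compounds sit at a limit of the assay rather than at a number: the limit of > 50 uM in this assay, at which 2 of the 4 values shown sit.

The compounds shown leave open whether the lower number goes with the piperazin-1-yl ring as a whole or with its hydrogen-bond donor, a question on which a morpholine ring, or a piperazine ring with a methyl group on its free nitrogen, at the same place on the core of compound 3 would bear. They also leave open how a pyrrolidine ring or a longer chain between the triple-bonded carbon and the amine would read on either core.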